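The compounds below may be only part of what the source reports. "The series", "measured", "known", "first", "only" and "open" are said of these compounds alone.

In a functional assay on a cell-free system (plasma) with sterol O-acyltransferase, Soat (Rattus norvegicus) as the target (a higher number here means that more compound is needed for the effect, a lower number that less compound is needed), compound 2, with the structure `O=C(Nc1c(F)cc(F)cc1F)N(Cc1ccccc1)Cc1cccc(-c2cc[nH]n2)c1`, gives 0.096 mg/kg. Compound 1, with the structure `Cc1cc(C)c(NC(=O)N(Cc2ccccc2)Cc2cccc(-c3cc[nH]n3)c2)c(C)c1`, is its close relative. In this assay compound 1 reaches only a limit of the measurement, > 1 mg/kg. Between the two lies one change, (2,4,6-trimethylphenyl in place of 2,4,6-trifluorophenyl on an amide-type nitrogen), and it brings an at least 10-fold higher number from compound 2 to compound 1 (1.01 log units; beyond the scatter). Because (the limit of > 1 mg/kg in this assay, at which 2 of the 3 values shown sit), that step can only be read as a lower bound on how much more compound is needed after the change.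

Compound 3, with the structure `O=C(Nc1c(F)cc(F)cc1F)N(Cc1ccc(-c2ccsc2)cc1)C1CCCCCC1`, carries the same 2,4,6-trifluorophenyl group as compound 2 but on a different core; how the two cores differ is not broken down here. In this assay compound 3 also sits at a limit, > 1 mg/kg.

Compound 4, with the structure `Cc1cc(C)c(NC(=O)N(Cc2ccc(-c3ccsc3)cc2)C2CCCCCC2)c(C)c1`, is still to be measured. It differs from compound 3 by 2,4,6-trimethylphenyl in place of 2,4,6-trifluorophenyl on an amide-type nitrogen, the same change that turned compound 2 into compound 1, at the same kind of place on the core. Since compound 3 already needs a dose at its limit, > 1 mg/kg, and since the same change made compound 1 need more than compound 2 by an at least 10-fold higher number from compound 2 to compound 1 (1.01 log units; beyond the scatter), compound 4 is expected to need a dose at or beyond that limit, a step estimated at a step that the limit leaves unreadable from compound 3 to compound 4. The expected value for compound 4 is 3 mg/kg, estimated to fall between 1 mg/kg and 10 mg/kg, and most likely the assay reports only a limit again.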

Compound 4, dose for half-maximal effect: 0.51 mg/kg
Beside the measured number, compound 4's estimate is 5.9-fold (0.77 log units) above it; measured number below the stated range.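

On the core of compound 3, putting 2,4,6-trimethylphenyl in place of 2,4,6-trifluorophenyl on the amide-type nitrogen gives an at least 1.9-fold lower number from compound 3 to compound 4 (0.29 log units; that floor lies within the scatter), so this step alone does not establish a real change. Set beside the step on the core of compound 2, however, it shows that in this assay the change does not carry over from one core to the other with the same effect: the same change on two cores in this assay, an at least 10-fold higher number (1.01 log units; beyond the scatter) from compound 2 to compound 1 and an at least 1.9-fold lower number (0.29 log units; that floor lies within the scatter) from compound 3 to compound 4, at least 20-fold (1.31 log units) apart, beyond the scatter of two such steps. This comparison shows only that the effect of the change depends on the core in these two pairs; it does not give the true size of either step or a reason for the difference, and both steps can be read only as bounds because each pair has one compound at the limit of the measurement: the limit of > 1 mg/kg in this assay, at which 2 of the 4 values shown sit.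

Still open, on these data alone, is which part of the two cores sets the outcome of the change, and whether a third core would follow compound 2 and compound 1 or compound 3 and compound 4. Also open, as far as these compounds go, is how other groups on the same nitrogen, such as a chlorine-bearing phenyl ring or a methoxy-bearing phenyl ring, would behave on each core.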